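This account rests on a few compounds, and the source may have more. Where it says the series, first, only, none or still open, it means among the compounds named here.

In a functional assay on A549 cells (Homo sapiens) for cytotoxicity, read by MTT assay, with a stated time of 48 h (on this read-out lower numbers stand for stronger inhibition and higher numbers for weaker inhibition), the three measured compounds stand as follows:

Compound 1, `O=C(N/N=C/c1ccccc1O)c1cc(-c2ccccc2)nn1Cc1ccc(Cl)nc1`: compound 1 gives 5920 nM
Compound 2, `O=C(N/N=C/c1ccccc1O)c1cc(-c2ccc(Cl)cc2)nn1Cc1ccc(Cl)nc1`: compound 2 gives 3660 nM
Compound 3, `O=C(N/N=C/c1ccccc1O)c1cc(-c2ccccc2)nn1Cc1ccccc1`: compound 3 gives 11000 nM

Compound 2 is compound 1 with one change, (chloro in place of hydrogen on an aromatic carbon). That change gave a 1.6-fold lower number from compound 1 to compound 2 (0.21 log units; within the scatter), a step that stays inside the usual spread of repeated measurements, so on its own it shows no clear gain or loss.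

Compound 3 differs from compound 1 in another spot, (phenyl in place of 6-chloropyridin-3-yl on a saturated chain carbon bound to an aromatic nitrogen). Here the step was a 1.9-fold higher number from compound 1 to compound 3 (0.27 log units; within the scatter), again within the scatter. The numbers for compound 2 and compound 3 lie further apart, but no single change links those two.

Compound 4, `O=C(N/N=C/c1ccccc1O)c1cc(-c2ccc(Cl)cc2)nn1Cc1ccccc1`, has not yet been tested. It is compound 3 carrying the same change that turned compound 1 into compound 2: chloro in place of hydrogen on an aromatic carbon. The surroundings of the change are described in the same words in both pairs, so it is the same change, made on a core that differs only in the part told above.

Because the matching step gave a 1.6-fold lower number from compound 1 to compound 2 (0.21 log units; within the scatter), a step of similar size, a 1.6-fold lower number from compound 3 to compound 4 (0.20 log units; within the scatter), is expected here, with wide uncertainty since a single within-scatter step is a thin basis. Compound 4 is therefore expected to give about 7000 nM in this assay, most likely between 3500 nM and 14000 nM.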

Compound 4, half-maximal inhibitory concentration: 4690 nM
Beside the measured number, compound 4's estimate is 1.5-fold (0.17 log units) above it, within the range that was stated.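

In this assay, putting chloro in place of hydrogen on the core of compound 3 gave a 2.3-fold lower number from compound 3 to compound 4 (0.37 log units; beyond the scatter), and this step does not differ meaningfully from the one seen on the core of compound 1: the same change on two cores in this assay, a 1.6-fold lower number (0.21 log units; within the scatter) from compound 1 to compound 2 and a 2.3-fold lower number (0.37 log units; beyond the scatter) from compound 3 to compound 4, 1.5-fold (0.16 log units) apart, within the scatter of two such steps The other change, phenyl in place of 6-chloropyridin-3-yl, was read on the chloro-bearing pair as a 1.3-fold higher number from compound 2 to compound 4 (0.11 log units; within the scatter), and it also matches its earlier counterpart: the same change on two cores in this assay, a 1.9-fold higher number (0.27 log units; within the scatter) from compound 1 to compound 3 and a 1.3-fold higher number (0.11 log units; within the scatter) from compound 2 to compound 4, 1.5-fold (0.16 log units) apart, within the scatter of two such steps So each change looks about the same on both cores, which fits with the two changes acting independently here, but that rests on two cores only, just one of the four steps lies beyond the scatter, and nothing here shows that the match would hold on a different core or explains why the numbers move.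

The compounds shown leave open whether a fluoro, a methoxy or an amine at the same place on the ring would behave as chloro does. They also leave open what a longer chain would do in place of the phenyl or 6-chloropyridin-3-yl group on the saturated chain carbon.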